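A few compounds are considered here, and "the series" means these few. Any claim that something is new, unique, unknown or untested is made for them only; others in the source may bear on it.

Compound 1, `COc1ccccc1N1CCN(CCCOc2ccccc2C(N)=O)CC1`: 18.2 mg/kg
Compound 2, `NC(=O)c1ccccc1OCCCCN1CCN(c2ccccc2)CC1`: > 40 mg/kg

In a functional assay on the whole organism (strain Swiss albino) for inhibition, with Mus musculus as the target, with stated times of 30 min, 10 min and 20 min, at a dose of 50 mg/kg by the subcutaneous route (a lower number here means that less compound is needed, a higher number that more compound is needed for the effect), compound 1 gives 18.2 mg/kg. Compound 2 stands at the limit of > 40 mg/kg in this assay, at which 1 of the 2 values shown sits, so for it the assay reports only a limit and no number; its true dose is not known, only that it lies beyond what the assay resolves.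

Compound 3, `COc1ccccc1N1CCN(CCCCOc2ccccc2C(N)=O)CC1`, has not been measured. It differs from compound 2 in one place: methoxy in place of hydrogen on an aromatic carbon. Among the compounds with values here, no measured pair shows this change on its own, so its effect can only be expected, not read off. The expectation is that the step from compound 2 to compound 3 in this assay goes downward, toward less compound being needed, by an amount beyond the usual scatter, since compound 1, which also carries the methoxy group, gives 18.2 mg/kg. For compound 2, by contrast, the assay reports only a limit.

Compound 3 is therefore estimated at 20 mg/kg, within 10 mg/kg to 40 mg/kg. The step of an at least 2.0-fold lower number from compound 2 to compound 3 (0.30 log units; that floor lies within the scatter) is what this estimate means.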

Compound 3, dose for half-maximal effect: > 40 mg/kg
Compound 3 ended at the assay's limit; the forecaster's own chance of this, stated with the estimate: 30%; middle value at least 2.0-fold (0.30 log units) from the limit.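

Compound 2 and compound 3 both end at a limit in this assay, so no step can be read between them: the limit of > 40 mg/kg in this assay, at which 2 of the 3 values shown sit.

From the compounds shown here alone, whether methoxy in place of hydrogen on an aromatic carbon changes the dose needed at all, and in which direction, stays open for these two compounds.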